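Two hydroxyls in place of fluorine on the hydrazone ring

A few compounds are considered here, and "the series" means these few. Any claim that something is new, unique, unknown or untested is made for them only; others in the source may bear on it.

Compound 1 `CN(C)CCn1cnnc1-c1cc(Oc2ccc(NC(=O)N/N=C/c3ccc(F)cc3)cc2F)ccn1` carries a 4-fluorophenyl group on a carbon with a double bond to nitrogen. Within the data shown here, in a functional assay on HT-29 cells (Homo sapiens) for cytotoxicity, read by MTT assay, with a stated time of 72 h (on this read-out lower numbers stand for stronger inhibition and higher numbers for weaker inhibition), compound 1 gives 1370 nM, the lower of the two numbers measured so far, though the other lies within the scatter of it. Compound 2 `CN(C)CCn1cnnc1-c1cc(Oc2ccc(NC(=O)N/N=C/c3ccc(O)c(O)c3)cc2F)ccn1` gives 1890 nM in this assay, and the step of a 1.4-fold higher number from compound 1 to compound 2 (0.14 log units; within the scatter) lies within the scatter. Compound 3 `CN(C)CCn1cnnc1-c1cc(Oc2ccc(NC(=O)N/N=C/c3ccc(O)cc3O)cc2F)ccn1` differs from compound 1 as follows: 2,4-dihydroxyphenyl in place of 4-fluorophenyl on a carbon with a double bond to nitrogen. Among the measured compounds shown here, the only measured step that bears on this change is the one from compound 1 to compound 2, where a dihydroxyphenyl group also replaced the 4-fluorophenyl group and the number stayed within the scatter; a similar outcome is expected here. Compound 3 is therefore expected to give about 1700 nM in this assay, with a likely range from 800 nM to 3600 nM. This estimate corresponds to an expected 1.2-fold higher number from compound 1 to compound 3 (0.09 log units; within the scatter), which is within the scatter.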

Compound 3, half-maximal inhibitory concentration: 52600 nM
Compound 3: the middle estimate sits 31-fold (1.49 log units) below what was measured; measured number outside the range, above it.
By their numbers in this assay, from the lowest: compounds 1 and 2 (each within the scatter of the next); then compound 3.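

In this assay, this position proves far more sensitive than the first pair suggested: 2,4-dihydroxyphenyl in place of 4-fluorophenyl gives a 38-fold higher number from compound 1 to compound 3 (1.58 log units; beyond the scatter) and a large loss of activity, whereas 3,4-dihydroxyphenyl had stayed within the scatter. Simply having two hydroxyl groups on this ring therefore does not set the outcome, and exchanging one dihydroxyphenyl group for the other gives a 28-fold higher number from compound 2 to compound 3 (1.44 log units; beyond the scatter) with only the arrangement of the hydroxyls changed. Nothing available explains why this arrangement behaves so differently.

The compounds shown leave open whether one hydroxyl group alone is enough to produce the loss, or whether both are needed. They also cannot tell whether a methoxy group or an amine in place of a hydroxyl would produce the same result.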